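This account rests on a few compounds, and the source may have more. Where it says the series, first, only, none or still open, it means among the compounds named here.

Of the compounds shown here, two have so far been measured in an assay on CHO cells for displacement of a labelled ligand from prostaglandin D2 receptor 2 (Homo sapiens), read by scintillation counting; a higher number here means a weaker inhibitor, a lower number a stronger inhibitor. Compound 1 `Cn1ccnc1C#Cc1cc(Cl)ccc1OCC(=O)O` gives 1470 nM in this assay. Compound 2 `Cc1ccc(S(=O)(=O)N(C)C(C)C)cc1C#Cc1cc(Cl)ccc1OCC(=O)O` gives 3.8 nM in this assay, the lowest of the two numbers, and the gap from compound 1 to compound 2 lies well beyond the scatter. Compound 2 therefore stands as the stronger inhibitor of the pair, with compound 1 far behind it.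

The next compound, compound 3 `Cc1ccc(S(=O)(=O)NC(C)(C)C)cc1C#Cc1cc(Cl)ccc1OCC(=O)O`, has not been measured. It keeps every atom of compound 2 but joins them differently: (tert-butyl)amino in place of isopropyl(methyl)amino on a sulfonyl sulfur. The change is confined to the sulfonamide nitrogen and its alkyl substituents; the rest of the molecule, including the shared core and the acid side chain, is untouched.

Among the compounds with values here, no step between measured compounds bears on this change, so the expectation rests on compound 2 alone. A modest step is expected, a 1.6-fold higher number from compound 2 to compound 3 (0.20 log units; within the scatter), most likely within the scatter or slightly toward a higher number. On that basis compound 3 is expected to give about 6 nM in this assay, within a range from 1.5 nM to 25 nM.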

Compound 3, inhibition constant: 5 nM
Estimate against measurement, compound 3: 1.2-fold (0.08 log units) above; low and high end bracket the measured number.
By their numbers in this assay, from the lowest: compounds 2 and 3 (each within the scatter of the next); then compound 1.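

In this assay the exchange of isopropyl(methyl)amino for (tert-butyl)amino on a sulfonyl sulfur amounts to a 1.3-fold higher number from compound 2 to compound 3 (0.12 log units; within the scatter) and so leaves the reading unchanged within the usual variation of this measurement. Until now this position was known from compound 2 alone; compound 3 shows that the same 5 heavy atoms can be joined differently here while the number stays in the low range set by compound 2. The difference in counted hydrogen-bond donors, 0 in isopropyl(methyl)amino and 1 in (tert-butyl)amino, therefore goes with no readable change in this pair, and nothing at hand explains why the two groups read alike.

The compounds shown leave open what a plain amino group, a smaller dimethylamino group or a ring amine such as morpholine or piperidine would give on the same sulfonyl sulfur. They also leave open whether the acid side chain, present unchanged in all three compounds, could be replaced by a longer carboxylic acid chain without losing the low number.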